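The source may report more compounds than this note shows. Statements on the series, on what has been measured and on what is new or still open speak of the compounds shown alone.

Measured so far in an ADME assay on Vero cells (Chlorocebus sabaeus) for cytotoxicity, read by MTT assay, with a stated time of 72 h; on this read-out lower numbers stand for higher toxicity in this test and higher numbers for lower toxicity in this test:
compound 1, `O[C@@H]1Cc2ccccc2N[C@H](c2ccccc2)C1`: > 300000 nM
compound 2, `O[C@@H]1Cc2cc(Br)ccc2N[C@H](c2ccccc2)C1`: 42100 nM
compound 3, `O[C@@H]1Cc2cc(F)ccc2N[C@H](c2ccccc2)C1`: > 300000 nM

Compound 1 reaches only the limit of this assay, so for compound 1 the value is a limit and not a number. Compound 3 also sits at that limit; this is the upper limit at which two of the three values stand (the limit of > 300000 nM in this assay, at which 2 of the 3 values shown sit). Compound 2 gives a number, and the step of an at least 7.1-fold lower number from compound 1 to compound 2 (0.85 log units; beyond the scatter) comes from bromo in place of hydrogen on an aromatic carbon of the shared core. The step that the two limits leave unreadable from compound 1 to compound 3 is unreadable, since both ends are limits, while an at least 7.1-fold higher number from compound 2 to compound 3 (0.85 log units; beyond the scatter) is clear.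

Compound 4, `O[C@@H]1Cc2ccccc2N[C@H](c2ccc(Cl)cc2)C1`, differs from compound 1 by chloro in place of hydrogen on an aromatic carbon, a halogen on the pendant ring rather than on the core. Among the measured steps only the two halogen introductions bear on it: bromo cut the number, fluoro left it at the limit. Chloro is expected to fall between, so for compound 4 an estimate of 150000 nM (range 40000 nM to 300000 nM) is made, the expected step being an at least 2.0-fold lower number from compound 1 to compound 4 (0.30 log units; that floor lies within the scatter).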

Compound 4, half-maximal cytotoxic concentration: > 300000 nM
Compound 4 gave a limit, no number; the forecaster's own chance of this, stated with the estimate: 45%; middle value at least 2.0-fold (0.30 log units) away from the limit.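

Within the data shown here, compound 1 and compound 4 both stand at a limit of the assay, not at a number, so no step between them can be read: the limit of > 300000 nM in this assay, at which 3 of the 4 values shown sit. The compounds shown leave open whether chloro in place of hydrogen here changes the number at all.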